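The compounds below may be only part of what the source reports. "The series", "measured", "known", "first", "only" and "open" are said of these compounds alone.

Measured so far in an assay on HEK293 cells for displacement of a labelled ligand from NPC1-like intracellular cholesterol transporter 1 (Homo sapiens); a lower number here means a stronger inhibitor, a higher number a weaker inhibitor:
compound 1, `COC(=O)CCCNC(=O)CN1CN(c2ccccc2)C2(CCN(C(=O)c3ccc(C4CCCCC4)cc3)CC2)C1=O`: 2500 nM
compound 2, `COC(=O)CCNC(=O)CN1CN(c2ccccc2)C2(CCN(C(=O)c3ccc(C4CCCCC4)cc3)CC2)C1=O`: 12900 nM
compound 3, `COC(=O)CCNC(=O)CN1CN(c2ccccc2)C2(CCN(C(=O)c3ccc(C(C)(C)C)cc3)CC2)C1=O`: "not determined" (no result reported)

Within the data shown here, compound 2 gives the highest of the two numbers; its nearest neighbour is compound 1, and the only measured step, a 5.2-fold higher number from compound 1 to compound 2 (0.71 log units; beyond the scatter), runs toward compound 2. Compound 4, `CC(C)(C)OC(=O)NCNC(=O)CN1CN(c2ccccc2)C2(CCN(C(=O)c3ccc(C4CCCCC4)cc3)CC2)C1=O`, differs from compound 2 in one place: (tert-butoxycarbonyl)amino in place of (methoxycarbonyl)methyl on a saturated chain carbon bound to an amide-type nitrogen. Among the measured compounds shown here, no measured step exchanges an ester-bearing group for a carbamate-bearing one, so the step from compound 1 to compound 2 bears on the change only in that it shows the chain end matters at a modest size. Compound 4 is therefore expected to land near compound 2, with wide uncertainty, the expected step being a 1.3-fold lower number from compound 2 to compound 4 (0.11 log units; within the scatter). The estimate for compound 4 in this assay is 10000 nM, between 3000 nM and 35000 nM.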

Compound 4, half-maximal inhibitory concentration: 1700 nM
For compound 4 the middle estimate is 5.9-fold (0.77 log units) above the measured one; measured number outside the range, below it.
By their numbers in this assay, from the lowest: compounds 4 and 1 (each within the scatter of the next); then compound 2.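

In this assay, the chain end tolerates a carbamate-bearing group as well as an ester-bearing one: (tert-butoxycarbonyl)amino in place of (methoxycarbonyl)methyl gives a 7.6-fold lower number from compound 2 to compound 4 (0.88 log units; beyond the scatter) on this saturated chain carbon bound to an amide-type nitrogen. Set against the 2-(methoxycarbonyl)ethyl group of compound 1, the same group gives a 1.5-fold lower number from compound 1 to compound 4 (0.17 log units; within the scatter), so these two chain ends are not separated in this assay. No measured evidence accounts for either step.

Open, going by these compounds, is whether a free amine in place of the (tert-butoxycarbonyl)amino group, or a carboxylic acid in place of the methyl ester, would keep the number of compound 4 or compound 1. Also open, on these data alone, is how a longer chain carrying the (tert-butoxycarbonyl)amino group would read.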